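The source may hold more compounds than are shown below. What is called first, only, known or untested is meant among the compounds shown, and "the series" means these compounds.

Three compounds with a shared core, differing in a single group on an aromatic carbon, have been measured in a physicochemical assay for solubility, measured as kinetic solubility, with a stated time of 15 h, at pH 7.4; on this read-out lower numbers stand for lower solubility and higher numbers for higher solubility. Compound 1 `Cc1cccc(-c2ccc(O[C@H]3O[C@H](CO)[C@@H](O)[C@H](O)[C@@H]3O)c(Cl)c2)c1` gives 7.1 ug/mL, compound 2 `OC[C@H]1O[C@H](Oc2ccc(-c3ccccc3Cl)cc2Cl)[C@@H](O)[C@@H](O)[C@@H]1O` gives 28 ug/mL, and compound 3 `O=[N+]([O-])c1ccc(-c2ccc(O[C@H]3O[C@H](CO)[C@@H](O)[C@H](O)[C@@H]3O)c(Cl)c2)cc1` gives 117 ug/mL. Compound 3 is thus the highest of the three, clearly separated from both of the others.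

The next structure, compound 4 `OC[C@H]1O[C@H](Oc2ccc(-c3ccc(Cl)c(Cl)c3)cc2Cl)[C@@H](O)[C@@H](O)[C@@H]1O`, keeps the core but carries 3,4-dichlorophenyl in place of 4-nitrophenyl on an aromatic carbon. Within the data shown here, two measured steps bear on this change, as both arrive at the 4-nitrophenyl group from another ring. One is modest, a 4.2-fold higher number from compound 2 to compound 3 (0.62 log units; beyond the scatter), and the other is large, a 16-fold higher number from compound 1 to compound 3 (1.22 log units; beyond the scatter). The step of a 3.9-fold higher number from compound 1 to compound 2 (0.60 log units; beyond the scatter) shows that swapping one group without a nitro group for another can also shift the number beyond the scatter. None of these steps tests the 3,4-dichlorophenyl group itself, so the size of the change remains uncertain.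

Losing the 4-nitrophenyl group is expected to reverse the direction of those two steps, giving a drop in this assay closer to the large one than the modest one. The expected step is a 13-fold lower number from compound 3 to compound 4 (1.11 log units; beyond the scatter). The estimated value for compound 4 is 9 ug/mL. The expected range runs from 2.5 ug/mL to 32 ug/mL.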

Compound 4, solubility: 2.3 ug/mL
Compound 4: middle estimate off by 3.9-fold (0.59 log units), on the high side, and the stated range ends above it.
By their numbers in this assay, from the lowest: compound 4; then compound 1; then compound 2; then compound 3.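

In this assay, the 3,4-dichlorophenyl group gives the lowest number of the four compounds, and each of its steps lies beyond the scatter (a 51-fold lower number from compound 3 to compound 4 (1.71 log units; beyond the scatter); a 12-fold lower number from compound 2 to compound 4 (1.09 log units; beyond the scatter); a 3.1-fold lower number from compound 1 to compound 4 (0.49 log units; beyond the scatter)). Among these compounds, the largest step now seen at this position is the one between the 4-nitrophenyl and 3,4-dichlorophenyl groups, so the position tolerates a wider spread than the earlier compounds revealed, even though both rings are carried on the same shared core. Chlorine on this ring does not set the outcome by itself, since compound 2 stands above compound 1 and compound 4 stands below it, and no measurement available here explains these differences.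

The compounds shown leave open whether the high number of compound 3 is tied to the nitro group or would also appear with a nitrile or a carboxylic acid in its place on the ring. An unsubstituted phenyl ring at this position would provide a plain reference point against which all four rings could be read.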